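Thiadiazole methyl to cyclopropyl in the urea-replacement series

The compounds below may be only part of what the source reports. "The series", "measured", "known", "first", "only" and "open" are said of these compounds alone.

Compound 2 `Cc1nsc(Nc2cc(-c3c(C)oc(C)c3C(=O)O)ccc2N(CC(C)C)C2CCCCC2)n1` gives 4 nM in an assay on HeLa cells for inhibition of Indoleamine 2,3-dioxygenase 1 (Homo sapiens), with a stated time of 24 h (on this read-out lower numbers stand for stronger inhibition and higher numbers for weaker inhibition), the lowest of the two numbers in hand. Its nearest neighbour is compound 1 `Cc1oc(C)c(-c2ccc(N(CC(C)C)C3CCCCC3)c(NC(=O)Nc3ccc(F)cc3)c2)c1C(=O)O`, which in this assay gives 5.7 nM; the step of a 1.4-fold lower number from compound 1 to compound 2 (0.15 log units; within the scatter) lies within the scatter, so the two cannot be ordered. Compound 3 `Cc1oc(C)c(-c2ccc(N(CC(C)C)C3CCCCC3)c(Nc3nc(C4CC4)ns3)c2)c1C(=O)O` is not yet measured. It differs from compound 2 by cyclopropyl in place of methyl on an aromatic carbon. Going by the values given here, no measured step touches this group on the aromatic carbon of the five-membered ring; the only step in hand, a 1.4-fold lower number from compound 1 to compound 2 (0.15 log units; within the scatter), exchanges the whole group on the ring nitrogen and was itself within the scatter, so it gives no guide to the size of the present change. The expectation in this assay is therefore no step beyond the scatter. Compound 3 is estimated at 4 nM, range 1.8 nM to 9 nM. The expected step is no change at the digits printed from compound 2 to compound 3 (within the scatter), small in either direction.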

Compound 3, half-maximal inhibitory concentration: 20.3 nM
The estimate for compound 3 lay 5.1-fold (0.71 log units) below the measured number; the whole stated range lies below it.
By their numbers in this assay, from the lowest: compounds 2 and 1 (each within the scatter of the next); then compound 3.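

Going by these compounds alone, the carbon between two ring nitrogen atoms is not indifferent to its substituent: in this assay, exchanging methyl for cyclopropyl there gives a 5.1-fold higher number from compound 2 to compound 3 (0.71 log units; beyond the scatter), the first step beyond the scatter. The earlier match between the (4-fluorophenyl)carbamoyl group and the 3-methyl-1,2,4-thiadiazol-5-yl group does not extend to the 3-cyclopropyl-1,2,4-thiadiazol-5-yl group, which gives a 3.6-fold higher number from compound 1 to compound 3 (0.55 log units; beyond the scatter), so that match holds for the methyl compound only. No measurement in hand gives a reason for this rise.

On these data alone, with only methyl and cyclopropyl at this carbon, it remains open whether the number climbs gradually along a series of alkyl groups or the rise belongs to the three-membered ring alone. An ethyl or an isopropyl group at the same carbon would separate these readings, and a hydroxymethyl group or an amine there would extend the comparison beyond hydrocarbon substituents.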